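The source may report more compounds than this note shows. Statements on the series, on what has been measured and on what is new or still open speak of the compounds shown alone.

Three amino alcohols with a long saturated chain were tested in a functional assay on SW1573 cells (Homo sapiens) for antiproliferative activity, read by sulforhodamine B assay, with a stated time of 48 h; a lower number here means a stronger inhibitor of growth, a higher number a weaker inhibitor of growth. Compound 1 `CCCCCCCCCCCCCCC[C@@H](O)[C@@H](N)[C@@H](C)O` gives 17000 nM. Compound 2 `CCCCCCCCCCCCCCC[C@@H](O)[C@@H](N)C(C)C` gives 7200 nM, and compound 3 `CCCCCCCCC[C@@H](O)[C@@H](N)C(C)C` gives 17000 nM. Compound 2 differs from compound 1 by one change, (1-hydroxyethyl in place of isopropyl on a saturated chain carbon bound to an amine nitrogen and a saturated chain carbon), and this change made a step of a 2.4-fold higher number from compound 2 to compound 1 (0.37 log units; beyond the scatter). Compound 2 also differs from compound 3 by hydrogen in place of hexyl on a saturated chain carbon, ten or more bonds along the chain from an oxygen on a saturated carbon, and that shortening of the chain made a step of a 2.4-fold higher number from compound 2 to compound 3 (0.37 log units; beyond the scatter). Compound 3 and compound 1 show no difference at the digits reported.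

Compound 4 `CCCCCCCCC[C@@H](O)[C@@H](N)[C@@H](C)O` has not yet been measured in this assay. Going by the values given here, its core differs from that of compound 2 by hydrogen in place of hexyl on a saturated chain carbon, ten or more bonds along the chain from an oxygen on a saturated carbon; on this shorter core the change 1-hydroxyethyl in place of isopropyl on a saturated chain carbon bound to an amine nitrogen and a saturated chain carbon is made, the same kind of change as the one from compound 2 to compound 1, at a place described in the same words. Because that earlier step was a 2.4-fold higher number from compound 2 to compound 1 (0.37 log units; beyond the scatter), the step from compound 3 to compound 4 is expected to be about a 2.4-fold higher number from compound 3 to compound 4 (0.38 log units; beyond the scatter) in this assay. Compound 4 is therefore estimated at 41000 nM, most likely between 15000 nM and 110000 nM, resting on a single earlier example of this change.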

Compound 4, concentration for 50% growth inhibition: 17000 nM
Compound 4: middle estimate off by 2.4-fold (0.38 log units), on the high side, and the stated range covers the measured number.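

In this assay, putting 1-hydroxyethyl in place of isopropyl on the shorter core gave no change at the digits printed from compound 3 to compound 4 (within the scatter), and removing hexyl from the longer chain gave no change at the digits printed from compound 1 to compound 4 (within the scatter). The 1-hydroxyethyl change can be said to carry over from one core to the other, since its two steps do not differ by more than the scatter: the same change on two cores in this assay, a 2.4-fold higher number (0.37 log units; beyond the scatter) from compound 2 to compound 1 and no change at the digits printed (within the scatter) from compound 3 to compound 4, 2.4-fold (0.37 log units) apart, within the scatter of two such steps The chain shortening reads the same way, but two pairs of compounds cannot show that either change keeps its size on other cores, and each change passes the scatter on one core and not on the other, so its true size stays unsettled: the same change on two cores in this assay, a 2.4-fold higher number (0.37 log units; beyond the scatter) from compound 2 to compound 3 and no change at the digits printed (within the scatter) from compound 1 to compound 4, 2.4-fold (0.37 log units) apart, within the scatter of two such steps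

The compounds shown leave open what a chain longer than that of compound 1 would give. They also leave open how another group, such as a carboxylic acid or an amine, would read on a saturated chain carbon bound to an amine nitrogen and a saturated chain carbon.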